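Extending compound 1 with a 2-methoxyphenyl group

This account rests on a few compounds, and the source may have more. Where it says the series, first, only, none or still open, it means among the compounds named here.

Measured compounds:
compound 1, `O=C(O)CCc1ccc(OCc2cccc(C(F)(F)F)c2)cc1`: 103%
compound 2, `O=C(O)CCc1ccc(NCc2ccc(-c3ccccc3)cc2)cc1`: 92%

Of the compounds shown here, two have been measured in a functional assay on 1321-N1 cells for agonist activity at Free fatty acid receptor 1 (Homo sapiens), read by calcium flux; a higher number here means a larger maximal response, a lower number a smaller maximal response. Compound 1, with the structure `O=C(O)CCc1ccc(OCc2cccc(C(F)(F)F)c2)cc1`, gives the higher of the two numbers, 103%. Compound 2, with the structure `O=C(O)CCc1ccc(NCc2ccc(-c3ccccc3)cc2)cc1`, gives 92%, a value that lies beyond the usual scatter below compound 1. For the measured compounds named here, the two compounds differ in more than one place, so their gap cannot be tied to a single change; it shows only that compound 1 stands at the top of what has been measured so far.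

The next compound, compound 3 with the structure `COc1ccccc1-c1cccc(COc2ccc(CCC(=O)O)cc2)c1`, is built from compound 1 by one change: 2-methoxyphenyl in place of trifluoromethyl on an aromatic carbon. The group that enters is considerably larger than the one that leaves and brings one ring with it. Going by the values given here, nothing measured so far isolates this particular exchange, so there is no step to lean on.

With compound 1 already near the top of the response scale, the expected step from compound 1 to compound 3 is a number 8 percentage points lower from compound 1 to compound 3 (within the scatter), small and most likely within the scatter, leaning downward if anywhere. Compound 3 is therefore estimated at 95%, with a range from 75% to 110%.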

Compound 3, largest response reached (reported as efficacy), in percent of the reference or control that the assay uses: 105%
Estimate against measurement, compound 3: 10 percentage points below; the range from low to high includes it.
By their numbers in this assay, from the lowest: compound 2; then compounds 1 and 3 (each within the scatter of the next).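

In this assay, the exchange of trifluoromethyl for 2-methoxyphenyl gives a number 2 percentage points higher from compound 1 to compound 3 (within the scatter), so the maximal response holds even though the entering group has 8 heavy atoms against 4 and brings a six-membered aromatic ring and a hydrogen-bond acceptor. For the compounds shown here, this pair is the first to isolate a single change, and it shows that this position, an aromatic carbon meta to a large group, can carry a much larger group with no change in response that stands out from the scatter. Nothing available explains why the response holds across this exchange.

As far as these compounds go, whether the methoxy group on the entering ring matters remains open, as does whether an amine or a carboxylic acid in its place would keep the response at the same level. The maximal response also does not show how much compound is needed to reach it, so this pair leaves open whether the exchange alters the concentration required, even though the top of the response stays level.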